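The source may report more compounds than this note shows. Statements on the series, on what has been measured and on what is new or still open speak of the compounds shown alone.

Three compounds share one core and differ only in the aromatic group on the five-membered ring. Compound 1 `CCCCCCCCc1ccc(OCC(=O)Cn2nnnc2-c2ccc(Cl)cc2)cc1` carries a 4-chlorophenyl group; in an assay on microsomes from brain for inhibition of Fatty-acid amide hydrolase 1 (Rattus norvegicus), read by fluorescence and HPLC, with a stated time of 60 min (a higher number here means a weaker inhibitor, a lower number a stronger inhibitor), compound 1 gives 130 nM. Compound 2 `CCCCCCCCc1ccc(OCC(=O)Cn2nnnc2-c2cccc(Cl)c2)cc1` carries a 3-chlorophenyl group, and in this assay compound 2 gives 360 nM. Compound 3 `CCCCCCCCc1ccc(OCC(=O)Cn2nnnc2-c2ccccc2Cl)cc1` carries a 2-chlorophenyl group, and in this assay compound 3 gives 4600 nM, the highest number of the three: the steps of a 35-fold higher number from compound 1 to compound 3 (1.55 log units; beyond the scatter) and a 13-fold higher number from compound 2 to compound 3 (1.11 log units; beyond the scatter) are both large, while a 2.8-fold higher number from compound 1 to compound 2 (0.44 log units; beyond the scatter) is modest.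

Compound 4 `CCCCCCCCc1ccc(OCC(=O)Cn2nnnc2-c2ccncc2)cc1` is not yet measured. It differs from compound 3 in one place: pyridin-4-yl in place of 2-chlorophenyl on an aromatic carbon. The 2-chlorophenyl group of compound 3 leaves, and with it the feature that set compound 3 apart from compounds 1 and 2. Going by the values given here, no measured compound bears a ring nitrogen in this group, so the weight of the pyridin-4-yl group itself is unknown. The two steps into compound 3 bear most directly on the change: both were large increases, and removing the 2-chlorophenyl group is expected to reverse a good part of them, giving a lower number. Compound 4 is therefore expected to reach about 350 nM in this assay, between 80 nM and 1500 nM, an expected step of a 13-fold lower number from compound 3 to compound 4 (1.12 log units; beyond the scatter).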

Compound 4, half-maximal inhibitory concentration: 190 nM
For compound 4 the middle estimate is 1.8-fold (0.27 log units) above the measured one, within the range that was stated.
By their numbers in this assay, from the lowest: compounds 1, 4 and 2 (each within the scatter of the next, the first and the last beyond it); then compound 3.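

In this assay, a ring nitrogen is tolerated at this position on the five-membered ring: the pyridin-4-yl group of compound 4 cannot be told apart from either chlorinated group that gave a low number, with a 1.5-fold higher number from compound 1 to compound 4 (0.16 log units; within the scatter) and a 1.9-fold lower number from compound 2 to compound 4 (0.28 log units; within the scatter). The third step, a 24-fold lower number from compound 3 to compound 4 (1.38 log units; beyond the scatter), shows that a number in this range does not require a chlorine on the aromatic ring, so that among the four compounds only compound 3, with its 2-chlorophenyl group, stands apart. Nothing at hand explains why these groups rank as they do.

The compounds shown leave open whether the high number of compound 3 belongs to the chlorine itself or would also come with a methyl group or a fluorine atom in its place. They also leave open how an unsubstituted phenyl group would compare with pyridin-4-yl, and whether pyridinyl groups with the ring nitrogen elsewhere in the ring would give numbers like that of compound 4.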